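A few compounds are considered here, and "the series" means these few. Any claim that something is new, unique, unknown or untested is made for them only; others in the source may bear on it.

Compound 1 `CCCCNc1nc(N)nc(C)c1I` gives 1640 nM in an assay on HEK293 cells for agonist activity at Toll-like receptor 8 (Homo sapiens), read by reporter gene assay (on this read-out lower numbers stand for an effect already at smaller amounts and higher numbers for an effect only at larger amounts of compound), compound 2 `CCCCNc1nc(N)nc(C)c1Cl` gives 20000 nM, and compound 3 `CCCCNc1cc(C)nc(N)n1` gives 22000 nM. Compound 3 thus carries the highest of the three numbers, though compound 2 lies within the scatter of it, while compound 1 stands well apart, as a 13-fold higher number from compound 1 to compound 3 (1.13 log units; beyond the scatter) shows. Compound 4 `CCCCNc1ccnc(N)n1` differs from compound 3 by hydrogen in place of methyl on an aromatic carbon. Going by the values given here, no measured step touches this methyl; the recorded steps concern the halogen site, where a 1.1-fold higher number from compound 2 to compound 3 (0.04 log units; within the scatter) was flat and a 12-fold higher number from compound 1 to compound 2 (1.09 log units; beyond the scatter) was large. Among the compounds with values here, with no comparable precedent, a step of the size a 1.1-fold higher number from compound 3 to compound 4 (0.06 log units; within the scatter) is expected, within the scatter. Compound 4 is therefore estimated at 25000 nM, expected between 8000 nM and 80000 nM.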

Compound 4, half-maximal effective concentration: 73200 nM
Compound 4: the middle estimate sits 2.9-fold (0.47 log units) below what was measured; the range from low to high includes it.
By their numbers in this assay, from the lowest: compound 1; then compounds 2 and 3 (each within the scatter of the next); then compound 4.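

Hydrogen in place of methyl on this aromatic carbon, next to the ring nitrogen, gives in this assay the first step at this position, a 3.3-fold higher number from compound 3 to compound 4 (0.52 log units; beyond the scatter), and it lies beyond the scatter. The methyl site therefore also moves the number, whereas replacing chloro with hydrogen at the halogen site did not. No measurement on hand explains this step.

The compounds shown leave open how an ethyl group, a longer chain or an amine would fare on this carbon. They also leave open whether removing the methyl costs the same with iodo on the core of compound 1.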